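Triazole Carboxamides: Swapping the Aryl Group on the Triazole Nitrogen

This account rests on a few compounds, and the source may have more. Where it says the series, first, only, none or still open, it means among the compounds named here.

Measured compounds:
compound 1, `Cc1c(C(=O)Nc2ccc(Oc3ccnc4[nH]ccc34)cc2)nnn1-c1ccccc1` — 420 nM
compound 2, `Cc1c(C(=O)Nc2ccc(Oc3ccnc4[nH]ccc34)cc2)nnn1-c1ccc(F)c(F)c1` — 2260 nM

In a functional assay on A549 cells (Homo sapiens) for cytotoxicity, read by MTT assay, with a stated time of 72 h (a higher number here means a weaker inhibitor, a lower number a stronger inhibitor), compound 2 gives 2260 nM, the higher of the two numbers; its nearest neighbour is compound 1, and the step of a 5.4-fold higher number from compound 1 to compound 2 (0.73 log units; beyond the scatter) separates them, brought about by 3,4-difluorophenyl in place of phenyl on an aromatic nitrogen.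

Compound 3, `Cc1c(C(=O)Nc2ccc(Oc3ccnc4[nH]ccc34)cc2)nnn1-c1ccc(Cl)c(C(F)(F)F)c1`, has not yet been measured. It differs from compound 2 by 4-chloro-3-(trifluoromethyl)phenyl in place of 3,4-difluorophenyl on an aromatic nitrogen, the new group sitting next to the ring nitrogen and next to the ring atom that bears a methyl group.

Among the compounds with values here, only one measured step bears on this change, a 5.4-fold higher number from compound 1 to compound 2 (0.73 log units; beyond the scatter), and it concerns a different pair of groups; it shows that altering the aryl on the triazole nitrogen can move the number by a modest amount. Within the data shown here, no step from a difluorophenyl to a chloro-trifluoromethylphenyl is available, so the direction is open. A step of about that size, in either direction, or none beyond the scatter, is therefore expected for a 1.5-fold lower number from compound 2 to compound 3 (0.18 log units; within the scatter). The estimate for compound 3 in this assay is 1500 nM, within 300 nM to 7000 nM.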

Compound 3, half-maximal inhibitory concentration: 2830 nM
Compound 3: middle estimate off by 1.9-fold (0.28 log units), on the low side, and the stated range covers the measured number.
By their numbers in this assay, from the lowest: compound 1; then compounds 2 and 3 (each within the scatter of the next).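

In this assay, the step to 4-chloro-3-(trifluoromethyl)phenyl from 3,4-difluorophenyl is a 1.3-fold higher number from compound 2 to compound 3 (0.10 log units; within the scatter), so these two substituted aryl groups cannot be told apart on the triazole nitrogen, even though the entering group is the larger by heavy atoms. Measured against plain phenyl, the same group gives a 6.7-fold higher number from compound 1 to compound 3 (0.83 log units; beyond the scatter), which places it with 3,4-difluorophenyl on the same side of phenyl, with no listed compound going against this among the three. No supporting measurement accompanies these numbers, so the reason for the separation from phenyl remains unknown.

The compounds shown leave open whether one substituent on the phenyl ring is enough to produce this separation, since both substituted rings carry a pair of groups and a lone fluorine or lone chlorine does not appear among them. They also leave open how the number would respond to a methoxy group, an amine or a carboxylic acid on that ring, or to a saturated cyclohexyl ring in place of the aryl group.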